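Phenyl for methyl at the benzylic chain of compound 3

This account rests on a few compounds, and the source may have more. Where it says the series, first, only, none or still open, it means among the compounds named here.

Compound 3, `CCc1cc(Cn2c(CC)nc3c(C)cc(C)nc32)ccc1OC(C(=O)O)c1ccccc1`: 410 nM
Compound 1, `CCCc1nc2c(C)ccnc2n1Cc1ccc(OC(C(=O)O)c2ccccc2)cc1`: 3400 nM
Compound 2, `CCc1nc2c(C)cc(C)nc2n1Cc1ccc(OC(C(=O)O)c2ccccc2C)cc1`: 5200 nM

In an assay on Midbrain with Type-2 angiotensin II receptor (Rattus norvegicus) as the target (a lower number here means a stronger inhibitor, a higher number a weaker inhibitor), compound 3 gives 410 nM, the lowest of the three numbers. Compound 1 gives 3400 nM and compound 2 gives 5200 nM; both lie beyond the scatter from compound 3, so compound 3 is the strongest inhibitor among the measured compounds. No two of the three differ in only one place, so no single step can be read from them.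

Compound 4, `CCc1nc2c(C)cc(C)nc2n1Cc1ccc(OC(C(=O)O)c2ccccc2)c(Cc2ccccc2)c1`, has not yet been measured in this assay. It differs from compound 3 in one place: phenyl in place of methyl on a saturated chain carbon bound to an aromatic carbon. Cut one bond further out, the same difference reads ethyl to benzyl. Going by the values given here, none of the measured compounds carries a phenyl at this position, so the data give no step that bears on this change. With nothing to anchor a direction, compound 4 is expected to stay close to compound 3, and the step of a 1.1-fold higher number from compound 3 to compound 4 (0.04 log units; within the scatter) is estimated to fall within the scatter, though a wide range must be allowed on either side. On that basis compound 4 is estimated at 450 nM, with a range from 120 nM to 1800 nM.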

Compound 4, half-maximal inhibitory concentration: 800 nM
Compound 4: middle estimate off by 1.8-fold (0.25 log units), on the low side; measured number inside the range.
By their numbers in this assay, from the lowest: compounds 3 and 4 (each within the scatter of the next); then compounds 1 and 2 (each within the scatter of the next).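

In this assay, the step of a 2.0-fold higher number from compound 3 to compound 4 (0.29 log units; within the scatter) lies within the scatter, so the two compounds cannot be told apart by their numbers. Going by these compounds alone, this gives the first reading at this position, as none of the three earlier compounds differed from another in only one place and none carried a phenyl here. On a saturated chain carbon bound to an aromatic carbon, a phenyl of 6 heavy atoms, including one six-membered aromatic ring, takes the place of a methyl of 1 heavy atom and leaves compound 4 level with compound 3, the strongest inhibitor of the earlier set, while no data here offer any explanation for that result.

The compounds shown leave open how an amine, a carboxylic acid or a longer alkyl chain such as propyl at this place would read in this assay. They also leave open whether a benzyl carrying a fluorine or a methoxy group on its ring would stay level with compound 4, and whether the same change would read alike on a different core.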